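A few compounds are considered here, and "the series" means these few. Any claim that something is new, unique, unknown or untested is made for them only; others in the source may bear on it.

In a functional assay on HEK293 cells for agonist activity at D(4) dopamine receptor (Homo sapiens), read by FLIPR (on this read-out higher numbers stand for an effect only at larger amounts of compound and lower numbers for an effect already at smaller amounts), compound 1 `Cc1cccc(NC(=O)CN2CCC(c3cccc(F)c3)CC2)c1` gives 512 nM. Among the three compounds with a number in hand, compound 1 stands second highest. Its nearest neighbour is compound 2 `O=C(NCN1CCC(c2cccc[n+]2[O-])CC1)c1cnccc1Cl`, which in this assay gives 1290 nM, a higher number, and that gap lies beyond the usual scatter. Furthest from it is compound 3 `[O-][n+]1ccccc1C1CCN(Cc2nc3ccccc3[nH]2)CC1`, which in this assay gives 54 nM, a much lower number, again beyond the scatter. Neither compound 2 nor compound 3 differs from compound 1 in one place only, so those gaps cannot be read as the effect of a single change.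

Compound 4 `Cc1cccc(NC(=O)CN2CCC(c3ccccc3C#N)CC2)c1` has not yet been measured in this assay. It differs from compound 1 in one place: 2-cyanophenyl in place of 3-fluorophenyl on a saturated ring carbon. Within the data shown here, no pair among the measured compounds shows this change, so there is no step to lean on, and the rest of compound 4 is the same as compound 1. The account therefore expects only a small step, if anything toward a higher number, and not clearly beyond the scatter; the expected step is a 1.4-fold higher number from compound 1 to compound 4 (0.14 log units; within the scatter). Compound 4 is expected to give about 700 nM in this assay, with a range from 250 nM to 2000 nM.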

Compound 4, half-maximal effective concentration: 8 nM
Beside the measured number, compound 4's estimate is 88-fold (1.94 log units) above it; the whole stated range lies above it.
By their numbers in this assay, from the lowest: compound 4; then compound 3; then compound 1; then compound 2.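

In this assay, replacing 3-fluorophenyl with 2-cyanophenyl on the saturated ring carbon gives a large step, a 64-fold lower number from compound 1 to compound 4 (1.81 log units; beyond the scatter), with the rest of the structure unchanged. The earlier compounds shown here offered no comparison in one place, whereas this pair shows that the number in this assay can depend strongly on the group held at this ring carbon. The change is nevertheless a single exchange of one whole group for another, in which the fluorine leaves, the nitrile enters and the numbering of the substituent differs, and nothing at hand accounts for the size of the step.

The compounds shown therefore leave open how much of the step belongs to the nitrile itself and how much to where it stands on the phenyl ring. They also leave open whether a trifluoromethyl group or a carboxylic acid in place of the nitrile would keep the number this low, and whether 2-cyanophenyl would give a similar step on a different core.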